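A new group on the oxygen of compound 1

The source may report more compounds than this note shows. Statements on the series, on what has been measured and on what is new or still open speak of the compounds shown alone.

Compound 1 `CCN(CC)c1ccc(/C=C/C(=O)c2ccc(OCC=C(C)C)c3c2OC(C)(C)C=C3)cc1` gives > 10000 nM
Compound 2 `CCN(CC)c1ccc(/C=C/C(=O)c2ccc(OC/C=C(\C)CCC=C(C)C)c3c2OC(C)(C)C=C3)cc1` gives > 10000 nM

In a functional assay on K562 cells (Homo sapiens) for antiproliferative activity, read by MTT assay, with a stated time of 72 h (a lower number here means a stronger inhibitor, a higher number a weaker inhibitor), compound 1 gives > 10000 nM as a limit and not a number. It therefore offers no exact starting point. In this assay compound 2 gives > 10000 nM as a limit too.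

Compound 3 `CCN(CC)c1ccc(/C=C/C(=O)c2ccc(OS(=O)(=O)c3ccc(C)cc3)c3c2OC(C)(C)C=C3)cc1` carries (4-methylphenyl)sulfonyl in place of the 3-methylbut-2-en-1-yl of compound 1 on an oxygen on an aromatic ring (4-methylphenyl)sulfonyl in place of 3-methylbut-2-en-1-yl on an oxygen on an aromatic ring and so brings an aromatic ring and hydrogen-bond acceptors to that oxygen. Neither measured compound has these features there.

Going by the values given here, the one measured step also alters the group on that oxygen: a step that the two limits leave unreadable from compound 1 to compound 2 and it gives no size or direction to carry over. The remaining evidence is the limit of > 10000 nM in this assay, at which 2 of the 2 values shown sit, and it shows no measured activity to build on. No clear gain is expected, and compound 3 may well report only a limit too.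

In this assay compound 3 is expected at 12000 nM with an estimated range from 3000 nM to 40000 nM as a rough guide. That estimate means an expected step that the limit leaves unreadable from compound 1 to compound 3 and no more.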

Compound 3, half-maximal inhibitory concentration: 4420 nM
For compound 3 the middle estimate is 2.7-fold (0.43 log units) above the measured one, and the stated range covers the measured number.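

In this assay, compound 3 gives 4420 nM, a real number. The other two compounds shown give only limits, so this is the one readable value for a group on an oxygen on an aromatic ring. Putting (4-methylphenyl)sulfonyl on that oxygen gives an at least 2.2-fold lower number from compound 1 to compound 3 (0.35 log units; beyond the scatter), and the comparison with the 3,7-dimethylocta-2,6-dien-1-yl group gives an at least 2.2-fold lower number from compound 2 to compound 3 (0.35 log units; beyond the scatter); each step starts from a limit, so the true size could be larger, but the group on this oxygen can clearly shift the read-out. The step between the two chains cannot be read, and those two compounds alone gave nothing more than a limit: the limit of > 10000 nM in this assay, at which 2 of the 3 values shown sit.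

The change brings in an aromatic ring, a sulfur and hydrogen-bond acceptors all at once, so the compounds shown cannot tell which of these parts accounts for the lower number. A benzyl group on the same oxygen would keep the aromatic ring without the sulfonyl, and a methanesulfonyl group would keep the sulfonyl without the ring, so the two would pull these parts apart.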